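Varying the aryl ring on a thiosemicarbazone scaffold

The source may hold more compounds than are shown below. What is called first, only, known or untested is meant among the compounds shown, and "the series" means these compounds.

Going by the values given here, in a functional assay on K562 cells (Homo sapiens) for cytotoxicity, read by sulforhodamine B assay (a lower number here means a stronger inhibitor of growth, a higher number a weaker inhibitor of growth), compound 2 `CC1=CC[C@@H]([C@@](C)(O)CCCC(C)(C)NC(=S)N/N=C\c2ccc(N(C)C)cc2)CC1` gives 42000 nM, the highest of the two numbers so far. Its nearest neighbour is compound 1 `CC1=CC[C@@H]([C@@](C)(O)CCCC(C)(C)NC(=S)N/N=C\c2ccc(O)cc2)CC1`, which in this assay gives 31100 nM, and the step between them, a 1.4-fold higher number from compound 1 to compound 2 (0.13 log units; within the scatter), lies within the scatter. Compound 3 `CC1=CC[C@@H]([C@@](C)(O)CCCC(C)(C)NC(=S)N/N=C\c2ccccc2[N+](=O)[O-])CC1` carries 2-nitrophenyl in place of 4-(dimethylamino)phenyl on a carbon with a double bond to nitrogen. Among the compounds with values here, only that one measured step bears on this change, and it was small, so no shift beyond the scatter is expected. Compound 3 is therefore estimated at 36000 nM, within a range of 15000 nM to 85000 nM. The expected step, a 1.2-fold lower number from compound 2 to compound 3 (0.07 log units; within the scatter), stays within the scatter.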

Compound 3, concentration for total growth inhibition: 7840 nM
Compound 3: the middle estimate sits 4.6-fold (0.66 log units) above what was measured; the measured number lies below the stated range.
By their numbers in this assay, from the lowest: compound 3; then compounds 1 and 2 (each within the scatter of the next).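

Swapping the aryl group on the carbon with a double bond to nitrogen can move the number in this assay beyond the scatter, which the step between the first two compounds did not show. Entry of 2-nitrophenyl gives a 5.4-fold lower number from compound 2 to compound 3 (0.73 log units; beyond the scatter) and also a 4.0-fold lower number from compound 1 to compound 3 (0.60 log units; beyond the scatter), so compound 3 inhibits growth more strongly than either earlier compound.

From the compounds shown here alone, whether a nitrile, a carboxylic acid or an amine in place of the nitro group would keep this gain remains open. Nothing measured here explains the gain.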